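Swapping an Alkyl Arm for a Fluorophenyl Ring

A few compounds are considered here, and "the series" means these few. Any claim that something is new, unique, unknown or untested is made for them only; others in the source may bear on it.

Going by the values given here, compound 2 `CCC(/C=C(\COC(C)=O)C(=O)c1ccccc1)CC` has the higher of the two numbers measured so far: in a functional assay on T47D cells (Homo sapiens) for inhibition, read by sulforhodamine B assay, with a stated time of 48 h (a lower number here means a stronger inhibitor of growth, a higher number a weaker inhibitor of growth), compound 2 gives 89000 nM. The nearest number belongs to compound 1 `O=C(/C(=C/c1ccc(Cl)cc1Cl)CCl)c1ccccc1`, which in this assay gives 6300 nM, a gap beyond the usual scatter. Compound 3 `CC(=O)OC/C(=C\c1ccccc1F)C(=O)c1ccccc1` differs from compound 2 by 2-fluorophenyl in place of pentan-3-yl on a double-bonded chain carbon bound to a double-bonded chain carbon. Among the compounds with values here, no measured pair shows this change, so the expectation rests on these two numbers alone. The expected step is a 5.9-fold lower number from compound 2 to compound 3 (0.77 log units; beyond the scatter), a clear decrease. For compound 3 the estimated value is 15000 nM, within a range from 4000 nM to 60000 nM.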

Compound 3, concentration for 50% growth inhibition: 18000 nM
Compound 3: middle estimate off by 1.2-fold (0.08 log units), on the low side; measured number inside the range.
By their numbers in this assay, from the lowest: compound 1; then compound 3; then compound 2.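

In this assay, going by these compounds alone, 2-fluorophenyl in place of pentan-3-yl gives a 4.9-fold lower number from compound 2 to compound 3 (0.69 log units; beyond the scatter), the first direct comparison at this position with the rest of the molecule unchanged. An aromatic ring on this double-bonded chain carbon therefore goes with stronger growth inhibition than pentan-3-yl in this single pair. No measurement shown here explains the step. This pair cannot separate the contribution of the ring from that of its fluorine. Going by these compounds, how a plain phenyl ring, or a phenyl ring carrying an amine, would compare remains open.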